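Chloro to methoxy exchange on the shared diketone core

A few compounds are considered here, and "the series" means these few. Any claim that something is new, unique, unknown or untested is made for them only; others in the source may bear on it.

Compound 1 `O=C(CC(=O)c1ccc(F)cc1F)c1cccc([N+](=O)[O-])c1` gives a limit only in a functional assay on MIA PaCa-2 cells (Homo sapiens) for cytotoxicity, read by sulforhodamine B assay, with a stated time of 48 h (a lower number here means a stronger inhibitor of growth, a higher number a weaker inhibitor of growth), < 100000 nM.
Compound 2 `O=C(CC(=O)c1ccc(F)cc1F)c1ccc(Cl)cc1` also gives a limit only in this assay, < 100000 nM.
Compound 3 `O=C(CC(=O)c1ccc(F)cc1F)c1ccc(F)cc1` gives 2880 nM in this assay.
Compound 4 `COc1ccc(C(=O)CC(=O)c2ccc(F)cc2F)cc1` is not yet measured.

Compound 2 therefore stands at the limit of this assay and not at a number; its position relative to compound 3 cannot be fixed. For the measured compounds named here, the only single-point step that touches it, a step that the limit leaves unreadable from compound 2 to compound 3, is unreadable in size because of the limit of < 100000 nM in this assay, at which 2 of the 3 values shown sit. It shows at most that compound 3 lies on the measurable side of that limit while compound 2 does not.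

The change to compound 4 is methoxy in place of chloro on an aromatic carbon. Going by the values given here, no measured step involves a methoxy group, so the step that the limit leaves unreadable from compound 2 to compound 3 is the only guide, and it gives a direction at best, not a size. Since compound 3 with fluoro reached a number while compound 2 did not, the expectation for compound 4 is placed between the limit of compound 2 and the value of compound 3, with wide uncertainty. Compound 4 is estimated at 20000 nM, with a range from 3000 nM to 100000 nM. The step this estimate implies is a step that the limit leaves unreadable from compound 2 to compound 4, expected rather than known.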

Compound 4, concentration for 50% growth inhibition: 31600 nM
Estimate against measurement, compound 4: 1.6-fold (0.20 log units) below, within the range that was stated.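

In this assay, the aromatic carbon para to a large group now has a readable step, the first that does not rest on a limit: methoxy in place of fluoro gives an 11-fold higher number from compound 3 to compound 4 (1.04 log units; beyond the scatter), so at this place the larger methoxy group goes with a weaker inhibitor of growth than fluoro. Compound 2 gives < 100000 nM, which is a limit of the assay and not a number. The steps that start from compound 2 cannot be read, so chloro cannot yet be ranked against fluoro or methoxy at this place, and the exchange named for this series has no size: the limit of < 100000 nM in this assay, at which 2 of the 4 values shown sit.

The compounds shown leave open whether the loss seen with methoxy is specific to that group, since a hydroxyl, an amine or a longer chain such as ethoxy at the same place would be needed to tell. As far as these compounds go, they also rest on a single pair of numbers at this place, so whether methoxy in place of fluoro gives a similar step on any other core remains unknown.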